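Dropping the Ethoxy Group from a Dithiocarbamate Lactone

The compounds below may be only part of what the source reports. "The series", "measured", "known", "first", "only" and "open" are said of these compounds alone.

Compound 1 `CCOc1ccccc1OCCSC(=S)N[C@H]1CCOC1=O`: 24100 nM
Compound 2 `CC(C)c1ccc(/C=C/C(=O)c2ccc(OCC(=O)N[C@H]3CCOC3=O)cc2)cc1`: 4660 nM
Compound 3 `O=C(COc1ccc(C(=O)/C=C/c2cccc(F)c2)cc1)N[C@H]1CCOC1=O`: 23200 nM

Of the compounds shown here, three have so far been measured in a functional assay on PC-3 cells (Homo sapiens) for antiproliferative activity, read by MTT assay, with a stated time of 72 h; a higher number here means a weaker inhibitor, a lower number a stronger inhibitor. Compound 1 gives the highest number of the three. Its nearest neighbour is compound 3, whose value lies within the scatter of that of compound 1, so the two cannot be told apart. For the measured compounds named here, compound 2 stands furthest away, with a clearly lower number, and the only step measured between compounds that differ in one place is a 5.0-fold higher number from compound 2 to compound 3 (0.70 log units; beyond the scatter), a modest change within the chalcone-type pair.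

Compound 4 `O=C1OCC[C@@H]1NC(=S)SCCOc1ccccc1` differs from compound 1 by hydrogen in place of ethoxy on an aromatic carbon. Going by the values given here, no measured pair shows what removing such a group from the aromatic ring does to this assay; the one step available concerns a different aryl swap in a different core and does not bear directly on it. With no guidance from the data, the expected step from compound 1 is a 1.0-fold higher number from compound 1 to compound 4 (0.02 log units; within the scatter), a change that is not expected to go beyond the scatter in either direction. Compound 4 is therefore estimated at 25000 nM, with a range from 8000 nM to 80000 nM.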

Compound 4, half-maximal inhibitory concentration: > 64000 nM
Compound 4: only a limit was reported; the forecaster's own chance of this, stated with the estimate: 10%; middle value at least 2.5-fold (0.40 log units) away from the limit.
By their numbers in this assay, from the lowest: compound 2; then compounds 3 and 1 (each within the scatter of the next). At a limit, above all of these: compound 4.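

For the compounds shown here, the first measured change at this position shows that the ethoxy group on the aromatic carbon, ortho to a large group, cannot be replaced by hydrogen without a loss in this assay: the swap gives an at least 2.6-fold higher number from compound 1 to compound 4 (0.42 log units; beyond the scatter), a step that the earlier compounds, with their single aryl swap in a different core, could not have revealed. As far as these compounds go, compound 4 has only a limit of > 64000 nM, not a number, so the direction of the change is established while its true size remains unknown. The step can therefore be read only as a lower bound, set by the top of the measured range: the limit of > 64000 nM in this assay, at which 1 of the 4 values shown sits.

The compounds shown leave open whether a methoxy group, a longer chain such as propoxy, or a hydroxyl group on this same aromatic carbon would keep the number near that of compound 1, or take it lower. They also do not tell whether adding ethoxy to the aromatic ring bearing the side chain in compound 2 or compound 3 would change the number in this assay.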